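This account rests on a few compounds, and the source may have more. Where it says the series, first, only, none or still open, it means among the compounds named here.

Compound 2 `Cc1ccc(NN=C2CCC(C)n3c2ncc(C(=O)O)c3=O)cc1C` stands on a limit of a functional assay on the whole organism with Rattus norvegicus as the target (a higher number here means that more compound is needed for the effect, a lower number that less compound is needed), and not on a number: in this assay compound 2 gives > 100 umol/kg. Compound 1 `CC1CCC(=NNc2ccccc2C(=O)O)c2ncc(C(=O)O)c(=O)n21` likewise returns only a limit in this assay, > 100 umol/kg. Compound 3 `Cc1cc(C)cc(NN=C2CCC(C)n3c2ncc(C(=O)O)c3=O)c1` also ends at a limit in this assay, > 320 umol/kg. Among the measured compounds shown here, the single step measured within the set, a step that the two limits leave unreadable from compound 2 to compound 3, has no readable size; the limit of > 100 umol/kg in this assay, at which 2 of the 3 values shown sit, and the limit of > 320 umol/kg in this assay, at which 1 of the 3 values shown sits, are all the set offers on it. Compound 4 `CC1CCC(=NNc2ccc(Br)cc2Cl)c2ncc(C(=O)O)c(=O)n21` carries 4-bromo-2-chlorophenyl in place of 3,4-dimethylphenyl on an amine nitrogen. For the measured compounds named here, no measured step bears on this change, so no direction can be read from the set. The expected step that the limit leaves unreadable from compound 2 to compound 4 is therefore taken as flat, with wide uncertainty. Compound 4 is estimated at 200 umol/kg, within 40 umol/kg to 1000 umol/kg.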

Compound 4, dose for 50% inhibition: > 100 umol/kg
Compound 4: no number, only a limit; the forecaster's own chance of this, stated with the estimate: 70%; the middle value lies beyond the limit too.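

Compound 4 also returns only a limit in this assay, > 100 umol/kg. Its steps from compound 2 and from compound 3 therefore cannot be read. On these data alone, whether the groups on the amine nitrogen change the dose at all remains open.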